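Turning the alcohol stereocentre: compound 2 to compound 3

The compounds below may be only part of what the source reports. "The series", "measured", "known", "first", "only" and "open" are said of these compounds alone.

Measured so far:
compound 1, `OC(CCn1nc2c(Br)c(Br)c(Br)c(Br)c2n1)c1cccc(Br)c1`, 52%
compound 2, `C[C@@H](O)CCn1nc2c(Br)c(Br)c(Br)c(Br)c2n1`, 105%

Of the compounds shown here, two sharing a tetrabrominated core have been measured in a functional assay on MCF7 cells (Homo sapiens) for antiproliferative activity, read by MTT assay, with a stated time of 24 h, tested at 25 uM; a lower number here means a stronger effect, a higher number a weaker effect of the compound at the concentration tested. Compound 1, `OC(CCn1nc2c(Br)c(Br)c(Br)c(Br)c2n1)c1cccc(Br)c1`, gives 52%. Among the compounds with values here, compound 2, `C[C@@H](O)CCn1nc2c(Br)c(Br)c(Br)c(Br)c2n1`, gives 105%, the highest of the two numbers, which here means the weaker effect; its only neighbour is compound 1, and the gap between them lies beyond the scatter. Within the data shown here, no single-point step between the two measured compounds can be drawn, as they differ in more than one place.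

Compound 3, `C[C@H](O)CCn1nc2c(Br)c(Br)c(Br)c(Br)c2n1`, is not yet measured. Its relation to compound 2 is computed from the two structures: the two compounds have the same atoms and bonds and differ only in configuration as drawn: 1 of 1 stereo elements differ; a stereocentre at a saturated chain carbon is drawn R in compound 2 and S in compound 3. Nothing measured here tells how this assay responds to configuration alone. With compound 2 at 105%, a value that shows no effect at the concentration tested, the account expects no step beyond the scatter, in either direction.

Compound 3 is therefore estimated at 100%, within 80% to 115%, an expected step of a number 5 percentage points lower from compound 2 to compound 3 (within the scatter).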

Compound 3, a percentage reported as activity, at one concentration (the size of the read-out at that concentration, not a potency): 102%
Beside the measured number, compound 3's estimate is 2 percentage points below it, and the stated range covers the measured number.
By their numbers in this assay, from the lowest: compound 1; then compounds 3 and 2 (each within the scatter of the next).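

In this assay, within the data shown here, this is the first reading of configuration at the saturated chain carbon that bears the alcohol, and it gives a number 3 percentage points lower from compound 2 to compound 3 (within the scatter), so at the concentration tested the assay does not separate the R drawing from the S drawing. The earlier pair could not show this, as compound 1 and compound 2 differ in more than one place and no single change could be read between them. The new step can be read as one of configuration alone because nothing else separates the two compounds: the fact that compounds 2 and 3 differ only in the configuration as drawn

Both compounds in this pair show no effect at the concentration tested, so whether configuration at this carbon matters in a compound that does have an effect stays open, and compound 1 has no partner of opposite configuration among the compounds shown to test it. Also open, from the compounds shown here alone, is how this assay would respond to an amine or a carboxylic acid in place of the alcohol, or to a longer chain on the shared core.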